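Thiadiazole and pyrazine sulfides in the writhing test

A few compounds are considered here, and "the series" means these few. Any claim that something is new, unique, unknown or untested is made for them only; others in the source may bear on it.

Measured so far, in a functional assay on the whole organism with Mus musculus as the target, in the writhing test; a higher number here means that more compound is needed for the effect, a lower number that less compound is needed:
- compound 1, `CCCCSc1nccnc1C1CN2CCC1CC2`, gives 3.2 mg/kg
- compound 2, `CCCCSc1nsnc1[C@@H]1CN2CCC[C@@H]1C2`, gives 0.19 mg/kg
- compound 3, `C=CCCCCOc1nsnc1C1=CCCN(C)C1`, gives 0.9 mg/kg

Compound 2 has the lowest number of the three in this assay. Its nearest neighbour on the numbers is compound 3, whose value stands beyond the scatter above it, and compound 1 stands further still; no pair among these three differs in a single place, so the values are read side by side and nothing more.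

Compound 4, `FC(F)(F)CCSc1nsnc1[C@@H]1CN2CCC[C@@H]1C2`, has not yet been measured. It differs from compound 2 in one place: trifluoromethyl in place of ethyl on a saturated chain carbon, two bonds along the chain from a sulfur. Read one bond further out, the chain goes from butyl to 3,3,3-trifluoropropyl, with the thiadiazole, the bicyclic amine and the sulfur untouched.

Among the measured compounds shown here, no measured pair shows what such a change does in this assay, so the expectation rests on compound 2 alone. The estimated step of a 1.6-fold higher number from compound 2 to compound 4 (0.20 log units; within the scatter) is small, with a slight lean toward a higher number. Compound 4 is expected to give about 0.3 mg/kg, within 0.1 mg/kg to 1 mg/kg.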

Compound 4, dose for half-maximal effect: 0.1 mg/kg
Estimate against measurement, compound 4: 3.0-fold (0.48 log units) above, and the stated range covers the measured number.
By their numbers in this assay, from the lowest: compounds 4 and 2 (each within the scatter of the next); then compound 3; then compound 1.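

In this assay, the exchange of trifluoromethyl for ethyl on a saturated chain carbon, two bonds along the chain from a sulfur, reads as a 1.9-fold lower number from compound 2 to compound 4 (0.28 log units; within the scatter). Among the compounds shown here, this is the first single-place comparison, and it shows that this position accepts the change from butyl to 3,3,3-trifluoropropyl with no step beyond the scatter. With that chain, compound 4 gives 0.1 mg/kg, so the two compounds cannot be ordered on these numbers.

Going by these compounds, whether the same exchange reads alike on the core of compound 1, and how a longer chain, an amine or a carboxylic acid would read in this place in this assay, stays open. No measurement shown offers a reason for this reading.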